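The source may report more compounds than this note shows. Statements on the series, on what has been measured and on what is new or still open speak of the compounds shown alone.

Measured compounds:
compound 1 `O=S(=O)(c1c[nH]c2ccc(Cl)cc12)C1CCNCC1` – 8.4 mg/kg
compound 2 `CN1CCC(Sc2cn(C)c3ccc(Cl)cc23)CC1` – 9.3 mg/kg

In a functional assay on the whole organism with Mus musculus as the target, in the hot plate test (on this read-out higher numbers stand for an effect only at larger amounts of compound and lower numbers for an effect already at smaller amounts), compound 2 gives 9.3 mg/kg, the higher of the two numbers, while compound 1 gives 8.4 mg/kg, which lies within the usual scatter of that figure. Compound 3 `CN1CCC(Sc2cn(C)c3ccc(Br)cc23)CC1` differs from compound 2 in one place: bromo in place of chloro on an aromatic carbon. Within the data shown here, no measured pair shows this exchange, so in this assay no step beyond the scatter is expected in either direction. Compound 3 is therefore expected to give about 9 mg/kg, with a range from 4.5 mg/kg to 18 mg/kg. The expected step of a 1.0-fold lower number from compound 2 to compound 3 (0.01 log units; within the scatter) stays within the scatter.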

Compound 3, dose for half-maximal effect: 8.6 mg/kg
Estimate against measurement, compound 3: 1.0-fold (0.02 log units) above; the measured number falls inside the stated range.
By their numbers in this assay, from the lowest: compounds 1, 3 and 2 (each within the scatter of the next).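

In this assay, bromo in place of chloro on this aromatic carbon gives a 1.1-fold lower number from compound 2 to compound 3 (0.03 log units; within the scatter), so compound 2 and compound 3 cannot be told apart. Among these compounds, compound 1 and compound 2 differ in more than one place, so this pair is the first to isolate this position, and here either halogen fits equally well. Nothing available explains this result.

As far as these compounds go, whether a group other than a halogen, such as methoxy or an amine, would be tolerated on this carbon remains open. So does whether the same exchange would give a similar result in the core of compound 1.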